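Bromo for Chloro on the Sulfonyl Aryl Ring

This account rests on a few compounds, and the source may have more. Where it says the series, first, only, none or still open, it means among the compounds named here.

Compound 3 `COc1ccc(-c2cc(=O)c3c(OC)cc(OC)cc3n2S(=O)(=O)c2ccc(Cl)cc2)cc1` is the point of departure. In an ADME assay on BJ cells (Homo sapiens) for antiproliferative activity, with a stated time of 72 h (on this read-out higher numbers stand for an effect only at larger amounts of compound and lower numbers for an effect already at smaller amounts), compound 3 gives only a limit of the assay, > 34400 nM, and no number. Its neighbour compound 2 `COc1ccc(-c2cc(=O)c3c(OC)cc(OC)cc3n2S(=O)(=O)c2ccc(F)cc2)cc1` is likewise known only as a limit, > 65500 nM, in this assay. Going by the values given here, compound 1 `C=CCNC(=O)n1c(-c2ccc(OC)cc2)cc(=O)c2c(OC)cc(OC)cc21`, which carries an allylcarbamoyl group on the aromatic nitrogen where the other two carry an arylsulfonyl, is the one compound with a plain number: in this assay compound 1 gives 74000 nM. The steps a step that the limit leaves unreadable from compound 1 to compound 2 and a step that the limit leaves unreadable from compound 1 to compound 3 cannot be sized, nor can a step that the two limits leave unreadable from compound 2 to compound 3, since the limit of > 34400 nM in this assay, at which 1 of the 3 values shown sits, and the limit of > 65500 nM in this assay, at which 1 of the 3 values shown sits, cap what the assay reports. Compound 4 `COc1ccc(-c2cc(=O)c3c(OC)cc(OC)cc3n2S(=O)(=O)c2ccc(Br)cc2)cc1` differs from compound 3 by bromo in place of chloro on an aromatic carbon. Among the compounds with values here, no measured step bears readably on this change, and every known value sits at or beyond the upper reach of this assay. Compound 4 is therefore expected to stay there as well, the step that the limit leaves unreadable from compound 3 to compound 4 being expected to lie within the scatter. The estimate for compound 4 in this assay is 60000 nM, between 30000 nM and 150000 nM, most likely returned only as a limit.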

Compound 4, half-maximal effective concentration: > 86200 nM
Compound 4: no number, only a limit; the forecaster's own chance of this, stated with the estimate: 70%; middle value at least 1.4-fold (0.15 log units) away from the limit.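

With bromo on the sulfonyl aryl ring, the fluoro, chloro and bromo compounds are all known only as limits in this assay; the steps among them cannot be read, and this change cannot be sized: the limit of > 86200 nM in this assay, at which 1 of the 4 values shown sits.

Compound 4 does give something that compound 2 and compound 3 did not, a readable step between an arylsulfonyl group and the allylcarbamoyl group: an at least 1.1-fold higher number from compound 1 to compound 4 (0.06 log units; that floor lies within the scatter). That step fixes only a floor and does not set the two groups apart.

As far as these compounds go, whether compound 2, compound 3 or compound 4 has a plain half-maximal value in this assay stays open, as their limits give none. Also open, from the compounds shown here alone, is whether an amine or a carboxylic acid in place of the halogen on the sulfonyl aryl ring would give a plain number in this assay.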